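Dropping the methoxy from compound 2: what to expect

The compounds below may be only part of what the source reports. "The series", "measured", "known", "first", "only" and "open" are said of these compounds alone.

Of the compounds shown here, two have been measured so far in an assay on HEK293 cells for displacement of a labelled ligand from Neuronal acetylcholine receptor; alpha4/beta2 (Homo sapiens); a lower number here means a stronger inhibitor, a higher number a weaker inhibitor. Compound 1, with the structure `Clc1ncc(N2CCCNCC2)cc1Br`, gives 1.41 nM. Compound 2, with the structure `COc1cc(N2CCNCC2)cnc1Br`, gives 182 nM. On these two numbers compound 2 stands highest; its nearest neighbour is compound 1, whose number lies far lower, well beyond the scatter of the assay. The two differ in more than one place, so nothing is said here about any single step between them; only their two values stand.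

Compound 3, with the structure `Brc1ccc(N2CCNCC2)cn1`, has not yet been measured. It is obtained from compound 2 by a single change, (hydrogen in place of methoxy on an aromatic carbon), which leaves the shared core otherwise untouched.

Within the data shown here, no measured step describes this change. Given that compound 2 gives 182 nM, compound 3 is expected to give a lower number, with a step estimated at a 4.6-fold lower number from compound 2 to compound 3 (0.66 log units; beyond the scatter), a moderate move rather than a large one. The estimate for compound 3 is therefore 40 nM, within a range from 6 nM to 250 nM.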

Compound 3, half-maximal inhibitory concentration: 182 nM
The estimate for compound 3 lay 4.6-fold (0.66 log units) below the measured number; measured number inside the range.
By their numbers in this assay, from the lowest: compound 1; then compounds 2 and 3 (each within the scatter of the next).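

In this assay, among these compounds, the step of no change at the digits printed from compound 2 to compound 3 (within the scatter) is the first comparison in this set between compounds that differ in one place, here hydrogen in place of methoxy on an aromatic carbon, ortho to a bromo group and two atoms from the ring nitrogen. On this core, then, the loss of the methoxy, with its 2 heavy atoms and 1 hydrogen-bond acceptor, leaves no mark on the number that can be told from the scatter. Nothing at hand gives a reason for this result.

From the compounds shown here alone, the pair speaks only for methoxy and hydrogen on this one core, so it remains open whether a fluoro group, a methyl group, an amine or a longer chain on the same carbon would also leave the number in place. Compound 1, at 1.41 nM in this assay, differs from compound 3 in more than one place, so the compounds shown do not tell which of those differences goes with its number.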